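A few compounds are considered here, and "the series" means these few. Any claim that something is new, unique, unknown or untested is made for them only; others in the source may bear on it.

Measured in a functional assay on HCT-116 cells (Homo sapiens) for cytotoxicity, read by MTT assay; on this read-out lower numbers stand for stronger inhibition and higher numbers for weaker inhibition:
- compound 1 `CSc1nc(NCc2ccc(C(=O)Nc3ccccc3N)cc2)n[nH]1`: 600 nM
- compound 2 `Nc1ccccc1NC(=O)c1ccc(CSc2ncc[nH]2)cc1`: 5000 nM

Compound 2 has the higher of the two numbers, so it is the weaker inhibitor here. Compound 3 `Nc1ccccc1NC(=O)c1ccc(CSc2nc3ccccc3[nH]2)cc1` has 1H-benzimidazol-2-yl in place of 1H-imidazol-2-yl on a sulfur. Going by the values given here, only one measured step exists, a modest one, an 8.3-fold higher number from compound 1 to compound 2 (0.92 log units; beyond the scatter). Among the compounds with values here, it changed a different group, so it offers only a loose guide to size, and no measured step tests this change directly. A modest shift toward a lower number in this assay is tentatively expected, a 2.5-fold lower number from compound 2 to compound 3 (0.40 log units; beyond the scatter). The estimated value for compound 3 is 2000 nM, with an expected range of 500 nM to 8000 nM.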

Compound 3, half-maximal inhibitory concentration: 300 nM
Compound 3: middle estimate off by 6.7-fold (0.82 log units), on the high side, and the stated range ends above it.
By their numbers in this assay, from the lowest: compounds 3 and 1 (each within the scatter of the next); then compound 2.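

In this assay the step to 1H-benzimidazol-2-yl on the sulfur gives a 17-fold lower number from compound 2 to compound 3 (1.22 log units; beyond the scatter) and is the first change shown at this position. The hydrogen-bond donor and acceptor counts of the group stay the same, so the gain comes with an added six-membered aromatic ring of carbon only and shows that this position responds strongly to such a change. Nothing available explains why the added ring has this effect.

As far as these compounds go, it remains open whether a chlorine atom or a methoxy group on the added ring would shift the number further. From the compounds shown here alone, it is also open whether a nitrogen in that ring would keep the gain.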